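This account rests on a few compounds, and the source may have more. Where it says the series, first, only, none or still open, it means among the compounds named here.

Compound 1 `C=C1CC[C@H]2[C@@](C)(CCC(=O)[C@@]2(C)COC(C)=O)[C@@H]1C/C=C1/C(=O)OC[C@@H]1Oc1c(Cl)cc(Cl)c2cccnc12` was tested in an ADME assay on Vero cells (Chlorocebus sabaeus) for cytotoxicity, read by MTT assay, with a stated time of 48 h (a lower number here means that less compound is tolerated, a higher number that more compound is tolerated), where compound 1 gives 57400 nM. This is the highest of the three numbers measured in this assay. The nearest is compound 2 `C=C1CC[C@@H]2[C@](C)(CO)[C@H](O)CC[C@@]2(C)[C@@H]1C/C=C1/C(=O)OC[C@H]1Oc1cccnc1[N+](=O)[O-]`, which in this assay gives 37700 nM; the two values lie within the scatter of each other, so no order between them can be read. The furthest is compound 3 `C=C1CC[C@H]2[C@@](C)(CCC(=O)[C@@]2(C)COC(C)=O)[C@@H]1C/C=C1/C(=O)OC[C@@H]1Oc1cccc2cccnc12`, which in this assay gives 12800 nM; here the step is a 4.5-fold lower number from compound 1 to compound 3 (0.65 log units; beyond the scatter). The two compounds differ in the aromatic part attached through the oxygen on a saturated carbon.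

Compound 4 `C=C1CC[C@H]2[C@@](C)(CCC(=O)[C@@]2(C)COC(C)=O)[C@@H]1C/C=C1/C(=O)OC[C@H]1Oc1c(Cl)cc(Cl)c2cccnc12` stands next to compound 1 in a different way: the two compounds have the same atoms and bonds and differ only in configuration as drawn: 1 of 6 stereo elements differ; a stereocentre at a saturated ring carbon is drawn R in compound 1 and S in compound 4. Among the compounds with values here, no measured pair among the three compounds differs only in configuration, so the one step that is known, from compound 1 to compound 3, concerns an exchange of aryl groups and does not bear on a change at a stereocentre. With nothing in the data speaking for a shift in either direction, the step from compound 1 to compound 4 in this assay is expected to be a 1.1-fold lower number from compound 1 to compound 4 (0.06 log units; within the scatter), that is, no change beyond the scatter. Compound 4 is therefore estimated to give 50000 nM in this assay, within a range from 20000 nM to 120000 nM.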

Compound 4, half-maximal cytotoxic concentration: 64700 nM
The estimate for compound 4 lay 1.3-fold (0.11 log units) below the measured number, within the range that was stated.
By their numbers in this assay, from the lowest: compound 3; then compounds 2, 1 and 4 (each within the scatter of the next).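

In this assay, the step to the other drawn configuration is a 1.1-fold higher number from compound 1 to compound 4 (0.05 log units; within the scatter), so this stereocentre at a saturated ring carbon gives no readable order between the two compounds. The earlier compounds shown here showed only an exchange of aryl groups, a 4.5-fold lower number from compound 1 to compound 3 (0.65 log units; beyond the scatter), and said nothing about configuration. This comparison isolates a single stereocentre, with the 5,7-dichloroquinolin-8-yl group and the rest of the core held the same: the fact that compounds 1 and 4 differ only in the configuration as drawn

The compounds shown leave open whether the two configurations would also stand within the scatter of each other with quinolin-8-yl in place of 5,7-dichloroquinolin-8-yl. They also leave open how the number in this assay would respond to an amine or a carboxylic acid in place of 5,7-dichloroquinolin-8-yl, in either configuration.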